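The source may hold more compounds than are shown below. What is called first, only, known or untested is meant among the compounds shown, and "the series" means these compounds.

Compound 1 `COc1ccc(-c2cn(-c3ccc(O)c(C(=O)Nc4cccc(C(F)(F)F)c4)c3)nn2)cc1` is tested in a functional assay on CCRF-CEM cells (Homo sapiens) for inhibition, read by MTT assay, with a stated time of 2 days, tested at 10 uM (on this read-out lower numbers stand for less inhibition and higher numbers for more inhibition at the one concentration tested (going by the name of the read-out)), where compound 1 gives 12%, the higher of the two numbers shown, though the other lies within the usual scatter. Compound 2 `COC(=O)c1cc(-n2cc(-c3cccc(O)c3)nn2)ccc1O` gives 5% in this assay. Compound 3 `O=C(Nc1cccc(C(F)(F)F)c1)c1cc(-n2cc(-c3cccc(O)c3)nn2)ccc1O` is not yet measured; it differs from compound 1 by 3-hydroxyphenyl in place of 4-methoxyphenyl on an aromatic carbon. Among the measured compounds shown here, no pair of measured compounds shows this change, so the expected step rests on the two values alone, and the step of a number 2 percentage points lower from compound 1 to compound 3 (within the scatter) is expected to be none beyond the scatter. Compound 3 is expected to give 10%, within a range from 0% to 25%.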

Compound 3, a percentage reported as inhibition, at one concentration (the size of the read-out at that concentration, not a potency): 13%
Beside the measured number, compound 3's estimate is 3 percentage points below it; the range from low to high includes it.
By their numbers in this assay, from the lowest: compounds 2, 1 and 3 (each within the scatter of the next).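

In this assay, among the compounds shown here, putting 3-hydroxyphenyl in place of 4-methoxyphenyl on an aromatic carbon of the five-membered aromatic ring gives a number 1 percentage points higher from compound 1 to compound 3 (within the scatter), the first direct reading of a change at this position. The hydrogen-bond donor that 3-hydroxyphenyl carries and 4-methoxyphenyl lacks therefore brings no change beyond the scatter in this core. No other measurement here bears on this result. Going by these compounds, whether an aminophenyl or a carboxylic acid-bearing phenyl at this position would give a different reading remains open.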